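From naphthalen-2-yl to 4-chlorophenyl on the shared core

This account rests on a few compounds, and the source may have more. Where it says the series, first, only, none or still open, it means among the compounds named here.

Measured in a functional assay on HeLa cells (Homo sapiens) for cytotoxicity, read by MTT assay, with a stated time of 48 h; on this read-out lower numbers stand for stronger inhibition and higher numbers for weaker inhibition:
- compound 1 `C=C(c1ccc(OC)cc1)c1cc(OC)c(OC)c(OC)c1-c1ccc(OC)cc1`: 72000 nM
- compound 2 `C=C(c1ccc(OC)cc1)c1cc(OC)c(OC)c(OC)c1-c1ccc(F)c(F)c1`: 5900 nM
- compound 3 `C=C(c1ccc(OC)cc1)c1cc(OC)c(OC)c(OC)c1-c1ccc2ccccc2c1`: 35000 nM

Compound 3 holds the middle place among these three numbers, with compound 1 higher and compound 2 lower. The gap on one side is small, a 2.1-fold lower number from compound 1 to compound 3 (0.31 log units; beyond the scatter), and the gap on the other is wider, a 5.9-fold higher number from compound 2 to compound 3 (0.77 log units; beyond the scatter).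

Compound 4 `C=C(c1ccc(OC)cc1)c1cc(OC)c(OC)c(OC)c1-c1ccc(Cl)cc1` has not yet been measured. Its difference from compound 3 is 4-chlorophenyl in place of naphthalen-2-yl on an aromatic carbon, with 4-chlorophenyl in place of naphthalen-2-yl on an aromatic carbon.

For the measured compounds named here, no measured step introduces this group, so the evidence is indirect. Going by the values given here, the closest guide is a 12-fold lower number from compound 1 to compound 2 (1.09 log units; beyond the scatter), a large step in which 3,4-difluorophenyl replaces 4-methoxyphenyl, and compound 2 is the only measured compound with halogen on that ring. The step of a 2.1-fold lower number from compound 1 to compound 3 (0.31 log units; beyond the scatter) shows that naphthalen-2-yl sits much nearer to 4-methoxyphenyl on these numbers. With a single halogenated example, only part of the drop seen for compound 2 is expected to carry over, so a modest fall in this assay is anticipated. The expected change is a 2.3-fold lower number from compound 3 to compound 4 (0.37 log units; beyond the scatter). For compound 4 the estimated value is 15000 nM, with an expected range of 5500 nM to 42000 nM.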

Compound 4, half-maximal inhibitory concentration: 30000 nM
Estimate against measurement, compound 4: 2.0-fold (0.30 log units) below, and the stated range covers the measured number.
By their numbers in this assay, from the lowest: compound 2; then compounds 4 and 3 (each within the scatter of the next); then compound 1.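

In this assay, 4-chlorophenyl in place of naphthalen-2-yl, one aromatic ring where there were two, gives a 1.2-fold lower number from compound 3 to compound 4 (0.07 log units; within the scatter) and so lies within the scatter, which means that this assay does not separate these two groups at this position on the shared core. Halogen on this ring does not by itself bring the number close to that of compound 2, as the step of a 5.1-fold higher number from compound 2 to compound 4 (0.71 log units; beyond the scatter) is beyond the scatter, and chloro in place of methoxy gives only a 2.4-fold lower number from compound 1 to compound 4 (0.38 log units; beyond the scatter) and stays well short of the large step to compound 2. No measurement shown here explains why the two halogenated rings differ in this way.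

As far as these compounds go, what remains open is whether the low number of compound 2 follows from fluorine as the halogen, from halogen at two ring positions or from the two together, a question that 4-fluorophenyl and 3,4-dichlorophenyl would help to separate. Also open is how this position would respond to a ring carrying an amine or a carboxylic acid, since every group shown here has no net charge.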